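Methyl in place of fluoro on the shared core

The source may report more compounds than this note shows. Statements on the series, on what has been measured and on what is new or still open speak of the compounds shown alone.

Measured in a functional assay on MGC-803 cells (Homo sapiens) for inhibition, read by MTT assay, with a stated time of 72 h; on this read-out lower numbers stand for stronger inhibition and higher numbers for weaker inhibition:
- compound 1 `CC(C)c1ccc(-c2nc(SCc3cn(CC(=O)NC(=O)Nc4ccccn4)nn3)nc(Nc3ccc(F)cc3)c2C#N)cc1`: 17500 nM
- compound 2 `CC(C)c1ccc(-c2nc(SCc3cn(CC(=O)NC(=O)Nc4ccccn4)nn3)nc(Nc3cccc(C(F)(F)F)c3)c2C#N)cc1`: > 64000 nM, a limit of the assay
- compound 3 `CC(C)c1ccc(-c2nc(SCc3cn(CC(=O)NC(=O)Nc4ccccn4)nn3)nc(Nc3ccccc3F)c2C#N)cc1`: > 64000 nM, a limit of the assay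

Compound 1 stands as the only number shown; the other two values sit at the limit of > 64000 nM in this assay, at which 2 of the 3 values shown sit. Replacing its 4-fluorophenyl by 3-(trifluoromethyl)phenyl gives an at least 3.6-fold higher number from compound 1 to compound 2 (0.56 log units; beyond the scatter), and by 2-fluorophenyl gives an at least 3.6-fold higher number from compound 1 to compound 3 (0.56 log units; beyond the scatter); between those two limits a step that the two limits leave unreadable from compound 2 to compound 3.

Compound 4 `Cc1ccc(Nc2nc(SCc3cn(CC(=O)NC(=O)Nc4ccccn4)nn3)nc(-c3ccc(C(C)C)cc3)c2C#N)cc1`, not yet measured in this assay, differs from compound 1 by methyl in place of fluoro on an aromatic carbon. Both measured steps moved the substituent to another place on that ring, and both were beyond the scatter; the step to compound 4 keeps the place and swaps only the group, so a smaller step is expected, if any, with the direction open. The estimate for compound 4 is therefore 22000 nM, within 8000 nM to 60000 nM, meaning a 1.3-fold higher number from compound 1 to compound 4 (0.10 log units; within the scatter).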

Compound 4, half-maximal inhibitory concentration: 3360 nM
The estimate for compound 4 lay 6.5-fold (0.82 log units) above the measured number, and the stated range ends above it.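

In this assay, the aromatic carbon para to a large group responds to the identity of its substituent, not only to where a substituent sits on the ring: methyl in place of fluoro gives a 5.2-fold lower number from compound 1 to compound 4 (0.72 log units; beyond the scatter), whereas both readable steps from compound 1 so far went to a higher number. The 4-methylphenyl group also separates clearly from the other two rings, with an at least 19-fold lower number from compound 3 to compound 4 (1.27 log units; beyond the scatter) and an at least 19-fold lower number from compound 2 to compound 4 (1.27 log units; beyond the scatter). Compound 2 and compound 3 stand only as limits of the assay, and the step between them cannot be read: the limit of > 64000 nM in this assay, at which 2 of the 4 values shown sit.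

Going by these compounds, only fluoro and methyl are compared at this place, so it remains open whether a longer chain such as ethyl, a methoxy group, chloro or an amine would move the number further, and in which direction.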